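Compound 3: an unsaturated chain in place of an ether chain

This account rests on a few compounds, and the source may have more. Where it says the series, first, only, none or still open, it means among the compounds named here.

In a functional assay on cells (Homo sapiens) for inhibition, read by MTT assay, with a stated time of 48 h (a higher number here means a weaker inhibitor, a lower number a stronger inhibitor), compound 1 `O=S(=O)(c1ccccc1)c1c(OCCCCCCO)no[n+]1[O-]` has no number, recorded as "not determined" (no result reported). For the measured compounds named here, compound 2 `O=C(COCCOc1no[n+]([O-])c1S(=O)(=O)c1ccccc1)NO` gives 19800 nM, the only number, so it cannot yet be ranked as strong or weak against any neighbour. Compound 3 `O=C(/C=C/COc1no[n+]([O-])c1S(=O)(=O)c1ccccc1)NO` keeps the shared core and the hydroxycarbamoyl end of compound 2 and changes only the chain: 2-(hydroxycarbamoyl)ethenyl in place of ((hydroxycarbamoyl)methoxy)methyl on a saturated chain carbon bound to an oxygen on an aromatic ring. Going by the values given here, no measured pair shows what such a change does in this assay, so only a modest step towards a lower number is expected, little beyond the usual scatter, and its direction is uncertain. The expected step is a 2.0-fold lower number from compound 2 to compound 3 (0.30 log units; within the scatter). For compound 3 the estimated value is 10000 nM, with an expected range of 3000 nM to 30000 nM.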

Compound 3, half-maximal inhibitory concentration: 57700 nM
Compound 3: the middle estimate sits 5.8-fold (0.76 log units) below what was measured, outside the stated range (above it).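

In this assay, for the compounds shown here, this change on a saturated chain carbon bound to an oxygen on an aromatic ring gives the first readable step: 2-(hydroxycarbamoyl)ethenyl in place of ((hydroxycarbamoyl)methoxy)methyl gives a 2.9-fold higher number from compound 2 to compound 3 (0.46 log units; beyond the scatter). The number therefore responds to the chain even with the shared core and the hydroxycarbamoyl end kept, and of this pair compound 2 is the stronger inhibitor. Nothing shown accounts for this step.

A single pair does not separate the part played by the chain oxygen from that of the double bond, and compound 1, at "not determined" (no result reported), adds no comparison. From the compounds shown here alone, whether a longer chain carrying the hydroxycarbamoyl end, or a carboxylic acid in place of that end, would move the number in either direction remains open.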